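Moving the benzimidazolyl attachment on a saturated ring carbon

The source may report more compounds than this note shows. Statements on the series, on what has been measured and on what is new or still open speak of the compounds shown alone.

Measured in an ADME assay on a cell-free system (plasma, Rattus norvegicus) for protein binding:
Compound 1 `Cc1ccc(C2CCN(Cc3cc(C(=O)O)c(=O)n4ccccc34)CC2)cc1`: 89%
Compound 2 `O=C(O)c1cc(CN2CCC(n3cnc4ccccc43)CC2)c2ccccn2c1=O`: 76%

Compound 2 has the higher unbound fraction of the two, and the gap to compound 1 lies beyond the scatter. Compound 3 `O=C(O)c1cc(CN2CCC(c3nc4ccccc4[nH]3)CC2)c2ccccn2c1=O` differs from compound 2 as follows: 1H-benzimidazol-2-yl in place of 1H-benzimidazol-1-yl on a saturated ring carbon. For the measured compounds named here, the one measured step that bears on this change is a 2.2-fold higher unbound fraction from compound 1 to compound 2 (0.34 log units; beyond the scatter), a modest step at the same ring carbon. The new change only joins the same atoms differently, so a smaller step is expected in this assay, with none beyond the scatter and a slight lean towards more binding. The expected step is a 1.2-fold lower unbound fraction from compound 2 to compound 3 (0.08 log units; within the scatter). For compound 3 the estimate is 80%, with an expected range from 62% to 91%.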

Compound 3, plasma protein binding in the plasma assay: 77%
Estimate against measurement, compound 3: 1.2-fold (0.06 log units) (unbound fraction) below; measured number inside the range.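

In the plasma assay compound 2 gives 76% and compound 3 gives 77%. In the plasma assay, the switch of attachment gives a 1.0-fold lower unbound fraction from compound 2 to compound 3 (0.02 log units; within the scatter), so at this saturated ring carbon the change from 1H-benzimidazol-1-yl to 1H-benzimidazol-2-yl, with its hydrogen-bond donor, does not move binding beyond the scatter. In the plasma assay, the other benzimidazolyl attachment also stands apart from 4-methylphenyl, with a 2.1-fold higher unbound fraction from compound 1 to compound 3 (0.32 log units; beyond the scatter). Nothing on hand explains this result.

In a physicochemical assay for lipophilicity (a higher number here means a more lipophilic compound, a lower number a more polar compound), compound 2 gives 0.92, while compound 3 gives "not determined" (no result reported), so the step between them cannot be read. Going by these compounds, whether a simple amine or a morpholine on this ring carbon would behave like the benzimidazolyl groups stays open.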